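Chloro on the pyridyl amide of compound 2

This account rests on a few compounds, and the source may have more. Where it says the series, first, only, none or still open, it means among the compounds named here.

Compound 2 `Cc1ccc(-c2cc(C(=O)Nc3ccncc3)nn2-c2ccc3ccccc3n2)cc1` stands second highest of the three numbers in a functional assay on MCF7 cells (Homo sapiens) for cytotoxicity, read by sulforhodamine B assay, with a stated time of 72 h (a higher number here means a weaker inhibitor, a lower number a stronger inhibitor), giving 15400 nM. Going by the values given here, compound 1 `Cc1ccc(-c2cc(C(=O)Nc3ccncc3Br)nn2-c2ccc3ccccc3n2)cc1` gives 11000 nM and compound 3 `COc1ncccc1NC(=O)c1cc(-c2ccc(C)cc2)n(-c2ccc3ccccc3n2)n1` gives 30200 nM; the step of a 1.4-fold higher number from compound 1 to compound 2 (0.15 log units; within the scatter) lies within the scatter, the step of a 2.0-fold higher number from compound 2 to compound 3 (0.29 log units; within the scatter) also within it, and only the step of a 2.7-fold higher number from compound 1 to compound 3 (0.44 log units; beyond the scatter) lies beyond. Compound 4 `Cc1ccc(-c2cc(C(=O)Nc3ccnc(Cl)c3)nn2-c2ccc3ccccc3n2)cc1` differs from compound 2 by chloro in place of hydrogen on an aromatic carbon, the chloro sitting next to the ring nitrogen, meta to the large group. The one halogen step shown, a 1.4-fold higher number from compound 1 to compound 2 (0.15 log units; within the scatter), moved the number little, so the expected step of a 1.4-fold lower number from compound 2 to compound 4 (0.15 log units; within the scatter) is also small, if anything toward a lower number. Compound 4 is therefore expected at 11000 nM, with a range from 5000 nM to 25000 nM.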

Compound 4, half-maximal inhibitory concentration: 3300 nM
For compound 4 the middle estimate is 3.3-fold (0.52 log units) above the measured one, outside the stated range (below it).
By their numbers in this assay, from the lowest: compound 4; then compounds 1, 2 and 3 (each within the scatter of the next, the first and the last beyond it).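

In this assay, chloro on the pyridine gives a 4.7-fold lower number from compound 2 to compound 4 (0.67 log units; beyond the scatter), the first halogen step from compound 2 that lies beyond the scatter, since bromo in compound 1 stayed within it. Compound 4 is the strongest of the four, with 2-chloropyridin-4-yl giving a 3.3-fold lower number from compound 1 to compound 4 (0.52 log units; beyond the scatter) and a 9.2-fold lower number from compound 3 to compound 4 (0.96 log units; beyond the scatter), although the first of these changes both the halogen and its place. No measurement shown bears on the reason for this result.

Going by these compounds, it remains open whether the halogen or its place carries the step. A 2-bromopyridin-4-yl or 2-aminopyridin-4-yl amide would test this.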